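The source may report more compounds than this note shows. Statements on the series, on what has been measured and on what is new or still open speak of the compounds shown alone.

In a physicochemical assay for solubility, in phosphate buffer, measured as kinetic solubility, at pH 7.4 (a higher number here means a more soluble compound, a lower number a less soluble compound), compound 3 `Cc1ccccc1-c1nc(CN2CCC(C(=O)NCCN3C[C@H](C)C[C@H](C)C3)CC2)c(C)o1` gives > 67 ug/mL as a limit, so its standing is known no better than that. Compound 1 `Cc1ccccc1-c1nc(CN2CCC(C(=O)NCCCN3CCCC(C(C)C)C3)CC2)c(C)o1` gives > 71 ug/mL as a limit too. Compound 2 `Cc1ccccc1-c1nc(CN2CCC(C(=O)NCCCN3CC4CCCC(C4)C3)CC2)c(C)o1` gives > 71 ug/mL as a limit as well. Compound 4 `Cc1ccccc1-c1nc(CN2CCC(C(=O)NCCCCN3C[C@H](C)C[C@H](C)C3)CC2)c(C)o1` differs from compound 3 by 2-(3,5-dimethylpiperidin-1-yl)ethyl in place of 3,5-dimethylpiperidin-1-yl on a saturated chain carbon, two bonds along the chain from an amide-type nitrogen with 2-(3,5-dimethylpiperidin-1-yl)ethyl in place of 3,5-dimethylpiperidin-1-yl on a saturated chain carbon. Among the compounds with values here, the steps that bear on this are a step that the two limits leave unreadable from compound 1 to compound 3 and a step that the two limits leave unreadable from compound 2 to compound 3 and neither has a readable size. No direction can be drawn from them, so nothing beyond the scatter is expected. The expected change is a step that the limit leaves unreadable from compound 3 to compound 4 in this reading. Compound 4 is estimated at 71 ug/mL with an expected range from 40 ug/mL to 85 ug/mL in this assay for now.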

Compound 4, solubility: > 71 ug/mL
Compound 4 ended at the assay's limit; the forecaster's own chance of this, stated with the estimate: 75%; the middle value lies on the limit itself.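

Compound 4, like compound 1, compound 2 and compound 3, gives only a limit in this assay, so no step among these compounds can be read. On these data alone, the actual read-out of each compound remains open.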